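Trifluoromethyl for methoxy on an aryl arm of compound 3

A few compounds are considered here, and "the series" means these few. Any claim that something is new, unique, unknown or untested is made for them only; others in the source may bear on it.

Three compounds carrying the shared core of compound 1 `COc1ccccc1/C=c1/[nH]c(=O)/c(=C\c2ccccc2OC)[nH]c1=O` have been examined in a functional assay on K562 cells (Homo sapiens) for cytotoxicity, read by CCK-8 assay, with a stated time of 72 h; on this read-out lower numbers stand for stronger inhibition and higher numbers for weaker inhibition. Compound 1 gives "not active" (no number reported). Compound 2 `C=CCn1c(=O)/c(=C\c2cccc(Br)c2)[nH]c(=O)/c1=C\c1ccccc1OC` gives 2400 nM, and compound 3 `C=CCn1c(=O)/c(=C\c2ccccc2OC)[nH]c(=O)/c1=C\c1ccccc1OC` gives 7400 nM. Going by the values given here, compound 3 therefore stands at the highest of the two numbers, with compound 2 as its nearest neighbour, and the only step between measured compounds runs a 3.1-fold higher number from compound 2 to compound 3 (0.49 log units; beyond the scatter).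

Compound 4 `C=CCn1c(=O)/c(=C\c2ccccc2C(F)(F)F)[nH]c(=O)/c1=C\c1ccccc1OC` differs from compound 3 in one place: trifluoromethyl in place of methoxy on an aromatic carbon. The step from compound 2 to compound 3 bears on this change, since it also exchanges a 2-methoxyphenyl for a differently substituted phenyl on the same chain carbon, and it gave a modest movement beyond the scatter. A halogen-bearing phenyl in place of the 2-methoxyphenyl thus lowered the number in this assay, and trifluoromethyl in place of methoxy removes the same hydrogen-bond acceptor. Compound 4 is accordingly expected to show a modest lowering, a 1.9-fold lower number from compound 3 to compound 4 (0.29 log units; within the scatter), with the size uncertain and a possible outcome within the scatter of compound 3. The estimate for compound 4 in this assay is 3800 nM, within a range from 1500 nM to 9500 nM.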

Compound 4, half-maximal inhibitory concentration: 2700 nM
For compound 4 the middle estimate is 1.4-fold (0.15 log units) above the measured one; low and high end bracket the measured number.
By their numbers in this assay, from the lowest: compounds 2 and 4 (each within the scatter of the next); then compound 3.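

In this assay, trifluoromethyl in place of methoxy on the same aromatic carbon gives a 2.7-fold lower number from compound 3 to compound 4 (0.44 log units; beyond the scatter), so the number responds to the identity of the group at this place alone; the earlier step had exchanged 2-methoxyphenyl for 3-bromophenyl and so changed both the group and its location on the ring at once. The second new step, a 1.1-fold higher number from compound 2 to compound 4 (0.05 log units; within the scatter), shows that the 2-(trifluoromethyl)phenyl and 3-bromophenyl arms cannot be told apart in this assay, while each stands apart from the 2-methoxyphenyl arm of compound 3, a statement that holds only for these three compounds with numbers. Nothing measured on these compounds gives a reason for this shift.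

From the compounds shown here alone, it remains open whether a chlorine, a methyl or an amine on this aromatic carbon would fall with compound 3 or with compound 4, and thus whether methoxy is the exception at this place. Also open, going by these compounds, is whether the same exchange of methoxy for trifluoromethyl would move the number on the second aryl arm, which keeps its 2-methoxyphenyl in compound 2, compound 3 and compound 4.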